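Replacing Dimethylsulfamoyl with Cyano, Starting from a Limit

The source may hold more compounds than are shown below. What is called first, only, known or untested is meant among the compounds shown, and "the series" means these compounds.

Of the compounds shown here, two have been tested in a physicochemical assay for solubility, in phosphate buffer, at pH 7.4; a higher number here means a more soluble compound, a lower number a less soluble compound. Compound 1 (`C[C@@H]1CN(C(=O)OC(C)(C)C)CCN1c1ncc(OCC2CCN(S(C)(=O)=O)CC2)cn1`) gives < 5000 nM, which is a limit of the assay and not a number. Compound 2 (`C[C@@H]1CN(C(=O)OC(C)(C)C)CCN1c1ncc(OCc2ccc(S(=O)(=O)N(C)C)cc2)cn1`) gives < 5000 nM, which is likewise only a limit. Both results therefore stand at one shared limit (the limit of < 5000 nM in this assay, at which 2 of the 2 values shown sit), and compound 2 has no exact value in this assay.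

Compound 3 (`C[C@@H]1CN(C(=O)OC(C)(C)C)CCN1c1ncc(OCc2ccc(C#N)cc2)cn1`) carries cyano in place of dimethylsulfamoyl on an aromatic carbon, para to a large group (cyano in place of dimethylsulfamoyl on an aromatic carbon). Within the data shown here, no measured pair shows what this change does. With only that shared limit to go on, the expected step that the limit leaves unreadable from compound 2 to compound 3 is no larger than the usual scatter, and a further limit is likely. For compound 3 the estimated value is 3000 nM, with an expected range from 1000 nM to 6000 nM.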

Compound 3, solubility: < 5000 nM
Compound 3: no number, only a limit (the forecaster's own chance of this, stated with the estimate: 80%); the middle value does not contradict the limit.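

Compound 3 also gives only a limit of the assay and not a number, so no step from compound 1 or compound 2 to compound 3 can be read: the limit of < 5000 nM in this assay, at which 3 of the 3 values shown sit.

The compounds shown leave open what exact value any of the three has, and whether cyano in place of dimethylsulfamoyl changes it at all.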